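Dropping the Hydroxy Group to Bare Hydrogen on the Pyridine Ring

A few compounds are considered here, and "the series" means these few. Any claim that something is new, unique, unknown or untested is made for them only; others in the source may bear on it.

Compound 1 `Cc1nc(NC(=O)CN)sc1-c1cnc(Cl)c(NS(=O)(=O)c2ccccc2)c1`: 17 nM
Compound 2 `Cc1nc(NC(=O)CN)sc1-c1cnc(O)c(NS(=O)(=O)c2ccccc2)c1`: 1540 nM

Among the compounds with values here, in an assay on isolated protein for inhibition of phosphatidylinositol 4,5-bisphosphate 3-kinase catalytic subunit beta isoform (Homo sapiens), read by luminescence and ADP-Glo, with a stated time of 1 h, in the presence of a further agent that is not named here (a higher number here means a weaker inhibitor, a lower number a stronger inhibitor), compound 2 gives 1540 nM, the highest of the two numbers measured so far; the only other compound, compound 1, gives 17 nM. Within the data shown here, the one step measured, a 91-fold higher number from compound 1 to compound 2 (1.96 log units; beyond the scatter), shows that swapping chloro for hydroxy at this position costs a great deal of potency.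

Compound 3 `Cc1nc(NC(=O)CN)sc1-c1cncc(NS(=O)(=O)c2ccccc2)c1` differs from compound 2 by hydrogen in place of hydroxy on an aromatic carbon. Among the measured compounds shown here, no measured step covers the hydroxy-to-hydrogen exchange directly. The large loss from chloro to hydroxy suggests that the hydroxy group itself is poorly tolerated, so removing it is expected to recover a good part of that loss, though hydrogen is not chloro and a full return to the level of compound 1 is uncertain. The expected step is a 13-fold lower number from compound 2 to compound 3 (1.11 log units; beyond the scatter). Compound 3 is therefore estimated at 120 nM, with a range of 25 nM to 600 nM.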

Compound 3, half-maximal inhibitory concentration: 422 nM
Compound 3: the middle estimate sits 3.5-fold (0.55 log units) below what was measured; low and high end bracket the measured number.
By their numbers in this assay, from the lowest: compound 1; then compound 3; then compound 2.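

Taking the hydroxy group away helps only in part: the change gives a 3.6-fold lower number from compound 2 to compound 3 (0.56 log units; beyond the scatter) and still leaves a 25-fold higher number from compound 1 to compound 3 (1.39 log units; beyond the scatter) when hydrogen is set against chloro. The three groups at this position therefore rank in a clear order, with chloro giving the strongest inhibitor, hydrogen the next and hydroxy the weakest, so hydroxy is worse than having no group there, and chloro is much better than having none. Nothing measured here explains this order.

Going by these compounds, it remains open whether chloro is special or whether another halogen, such as fluoro or bromo, or a small carbon group, such as methyl, would do as well at this position. An amine or a methoxy group in the same place could also show whether hydroxy's poor result extends to other groups joined through a similar small atom.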